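Notes on a butyl-to-cyclopentyl exchange in an antiproliferative series

The compounds below may be only part of what the source reports. "The series", "measured", "known", "first", "only" and "open" are said of these compounds alone.

Measured so far:
compound 1 `CCCCn1cnc2c(Nc3ccccc3)nc(NCOCc3ccc(/C=C/C(=O)Nc4ccccc4N)cc3)nc21`: 59.3%
compound 2 `COC(CCn1cnc2c(NCc3ccc(C(=O)Nc4ccccc4N)cc3)nc(Cl)nc21)OC`: 34.2%

In a functional assay on HepG2 cells (Homo sapiens) for antiproliferative activity, read by CCK-8 assay, with a stated time of 72 h, tested at 8 uM (on this read-out lower numbers stand for a weaker effect and higher numbers for a stronger effect at the one concentration tested), compound 1 gives 59.3%, the higher of the two numbers recorded. Compound 2 gives 34.2% in this assay, a gap that lies beyond the scatter of repeated measurements.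

Compound 3 `Nc1ccccc1NC(=O)/C=C/c1ccc(COCNc2nc(Nc3ccccc3)c3ncn(C4CCCC4)c3n2)cc1` has not been measured. It differs from compound 1 by cyclopentyl in place of butyl on an aromatic nitrogen. Among the compounds with values here, no step between two measured compounds bears on this change, so no direction can be read from the numbers. The expected step of a number 1.3 percentage points lower from compound 1 to compound 3 (within the scatter) is estimated to be small and within the scatter. Compound 3 is therefore expected to give 58%, with a range from 40% to 75%.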

Compound 3, a percentage reported as inhibition, at one concentration (the size of the read-out at that concentration, not a potency): 18.8%
Beside the measured number, compound 3's estimate is 39.2 percentage points above it; the measured number lies below the stated range.
By their numbers in this assay, from the lowest: compound 3; then compound 2; then compound 1.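

In this assay cyclopentyl in place of butyl on the aromatic nitrogen gives a number 40.5 percentage points lower from compound 1 to compound 3 (beyond the scatter) and shows that this position is not indifferent to the group it carries. Replacing the open chain with a ring of carbon is enough to lose much of the effect at the one concentration tested. No measurement here bears on the reason for this step.

Going by these compounds, whether a longer chain such as hexyl or a smaller ring such as cyclopropyl would hold the level of compound 1 remains open. These compounds also cannot separate the presence of a ring from the size of the group.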